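Para-chloro analogue of a flat cytotoxicity series

This account rests on a few compounds, and the source may have more. Where it says the series, first, only, none or still open, it means among the compounds named here.

Measured compounds:
compound 1 `O=c1oc2ccccc2c2nc3c(ccc4cc[nH]c43)c(-c3ccc(C(F)(F)F)cc3)c12`, 70700 nM
compound 2 `O=c1oc2ccccc2c2nc3c(ccc4cc[nH]c43)c(-c3cccc(Br)c3)c12`, 70700 nM
compound 3 `O=c1oc2ccccc2c2nc3c(ccc4cc[nH]c43)c(-c3ccc(Br)cc3)c12`, 70700 nM

In a functional assay on B16-F10 cells (Mus musculus) for cytotoxicity (a higher number here means a weaker inhibitor, a lower number a stronger inhibitor), compound 1 gives 70700 nM, and compounds 2 and 3 sit level with it. The two recorded steps from compound 1 are both flat: no change at the digits printed from compound 1 to compound 2 (within the scatter) and no change at the digits printed from compound 1 to compound 3 (within the scatter). The step between the two bromo analogues is flat as well, no change at the digits printed from compound 2 to compound 3 (within the scatter). Across the three measured compounds, then, the group on the pendant phenyl ring has been swapped in kind and in position without moving the read-out beyond the scatter.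

Compound 4 `O=c1oc2ccccc2c2nc3c(ccc4cc[nH]c43)c(-c3ccc(Cl)cc3)c12` is the next member: chloro in place of trifluoromethyl on an aromatic carbon. This change has a close precedent in the step from compound 1 to compound 3, where a single halogen also took the place of trifluoromethyl at the same aromatic carbon and the read-out did not move. With every measured step flat, no shift beyond the scatter is expected for compound 4 in this assay, so the estimated step of no change at the digits printed from compound 1 to compound 4 (within the scatter) is essentially zero. Compound 4 is therefore expected to give about 70700 nM, within a range of 35000 nM to 141000 nM.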

Compound 4, half-maximal inhibitory concentration: 70700 nM
Compound 4: middle estimate and measured number agree at the digits printed, and the stated range covers the measured number.
By their numbers in this assay, from the lowest: compounds 1, 2, 3 and 4 (each within the scatter of the next).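

Compound 4 puts one heavy atom, chloro, on this aromatic carbon where trifluoromethyl has four, and in this assay the outcome is no change at the digits printed from compound 1 to compound 4 (within the scatter) even with that difference in size. Among the compounds shown here, it also gives the first comparison of two single halogens at the same carbon, para to a large group, with no change at the digits printed from compound 3 to compound 4 (within the scatter) as the result, while the comparison of 4-chlorophenyl with 3-bromophenyl, which changes both the halogen and its place on the ring, shows no change at the digits printed from compound 2 to compound 4 (within the scatter) as well. The flat read-out now holds for trifluoromethyl and for both halogens at this carbon, but nothing available here bears on why these changes leave it unmoved.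

The compounds shown carry only halogen-bearing groups on the pendant phenyl ring, so it stays open whether an amine, a carboxylic acid, a hydroxyl group or a longer chain on that ring would leave the read-out equally flat. They also leave open whether a change to the shared core itself, rather than to this pendant ring, would shift the number at all.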